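This account rests on a few compounds, and the source may have more. Where it says the series, first, only, none or still open, it means among the compounds named here.

Measured so far in a physicochemical assay for solubility, at pH 1.1; on this read-out higher numbers stand for higher solubility and lower numbers for lower solubility
- compound 1 (`C[C@@H](c1ccc(Cl)cc1)N(Cc1ccc(OCCN2C(=O)CCC2=O)c(C(=O)O)c1)CC1CCCC1`): 3000000 nM
- compound 2 (`Cc1cc(CN(C)C(CC(=O)O)c2ccc(Cl)cc2)ccc1OCCn1c(=O)ccn(C)c1=O`): 3000000 nM

Compound 2 at 3000000 nM stands level with compound 1 at the digits shown, so the two are not separated in this assay beyond the scatter. Compound 3 (`CCCN(Cc1ccc(OCCn2c(=O)ccn(C)c2=O)c(C)c1)C(CC(=O)O)c1ccc(Cl)cc1`) is the next one to be read. It carries ethyl in place of hydrogen on a saturated chain carbon bound to an amine nitrogen, which turns methyl into propyl (ethyl in place of hydrogen on a saturated chain carbon bound to an amine nitrogen). Going by the values given here, no pair of measured compounds differs in one place only, so the series offers no direct measure of what such a change does. Two compounds are also a thin basis for any trend. The working expectation is no shift beyond the scatter in this assay, with any small movement more likely downward than upward. This rests only on compound 2 at 3000000 nM and compound 1 at 3000000 nM reading level. The expected 1.2-fold lower number from compound 2 to compound 3 (0.08 log units; within the scatter) therefore stays within the scatter. Compound 3 is estimated at 2500000 nM, with an expected range of 1200000 nM to 4000000 nM.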

Compound 3, solubility: 3000000 nM
For compound 3 the middle estimate is 1.2-fold (0.08 log units) below the measured one; the range from low to high includes it.
By their numbers in this assay, from the lowest: compounds 1, 2 and 3 (each within the scatter of the next).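

In this assay, the series now has its first comparison in one place: no change at the digits printed from compound 2 to compound 3 (within the scatter), with ethyl in place of hydrogen on a saturated chain carbon bound to an amine nitrogen, the same difference as methyl to propyl. This position therefore accepts an ethyl group, with 2 heavy atoms (2 carbon), no ring and no net charge, without a step beyond the scatter in this read-out, something compounds 1 and 2 could not show as they differ in more than one place. No measured information is available to explain this result.

Still open, from the compounds shown here alone, is whether a longer chain such as butyl, a ring such as cyclopropyl or a chain ending in an amine would read the same at this place. Also open, going by these compounds, is whether a single change elsewhere in compound 3, such as an amide in place of the carboxylic acid, would give a step beyond the scatter in this assay.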